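The source may report more compounds than this note shows. Statements on the series, on what has been measured and on what is new or still open speak of the compounds shown alone.

Going by the values given here, compound 1 `CC(C)c1c(C(=O)N(C)Cc2ccccc2)nn(-c2ccc(F)cc2)c1CC[C@@H](O)C[C@@H](O)CC(=O)O` and compound 2 `CC(C)c1c(C(=O)N2CCC[C@H](N3CCC4C=CC=CC4C3)C2)nn(-c2ccc(F)cc2)c1CC[C@@H](O)C[C@@H](O)CC(=O)O` are the two measured members of this set. In a functional assay on L6 cells (Rattus norvegicus) for inhibition (on this read-out higher numbers stand for weaker inhibition and lower numbers for stronger inhibition), compound 1 gives 2870 nM, and compound 2 gives 1720 nM. Compound 3 `CC(C)c1c(C(=O)NCc2ccccn2)nn(-c2ccc(F)cc2)c1OC[C@@H](O)C[C@@H](O)CC(=O)O` shares the same core but carries a different linker to the dihydroxy acid chain; in this assay compound 3 gives "not determined" (no result reported), so it stands nowhere on these numbers. Compound 4 `CC(C)c1c(C(=O)N(C)Cc2ccc(F)c(F)c2)nn(-c2ccc(F)cc2)c1OC[C@@H](O)C[C@@H](O)CC(=O)O` follows from compound 3 by the change ((3,4-difluorobenzyl)(methyl)amino in place of ((pyridin-2-yl)methyl)amino on a carbonyl carbon). Since compound 3 has no value, no step size can be given for it; compound 4 is expected to fall in the same broad region as compound 1, whose amide is built in a similar way. Compound 4 is therefore estimated at 2000 nM, with a range from 500 nM to 8000 nM.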

Compound 4, half-maximal inhibitory concentration: 4570 nM
The estimate for compound 4 lay 2.3-fold (0.36 log units) below the measured number; the measured number falls inside the stated range.
By their numbers in this assay, from the lowest: compounds 2, 1 and 4 (each within the scatter of the next, the first and the last beyond it).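

Going by these compounds alone, compound 3 has no number, so no step from it to compound 4 can be read, and no other evidence bears on this result. On these data alone, what replacing ((pyridin-2-yl)methyl)amino with (3,4-difluorobenzyl)(methyl)amino does to inhibition stays open.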